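A few compounds are considered here, and "the series" means these few. Any claim that something is new, unique, unknown or untested is made for them only; others in the source may bear on it.

Measured compounds:

Compound 1, `CCc1nc2c(-c3ccc(Cl)cc3Cl)ccnc2n1[C@@H](CC)C1CC1`, in an assay for binding affinity to Corticotropin releasing factor receptor (Rattus norvegicus) (on this read-out higher numbers stand for weaker inhibition and lower numbers for stronger inhibition), compound 1 gives 0.4 nM.
Compound 3, `CCc1nc2c(-c3ccc(C(F)(F)F)cc3Cl)ccnc2n1C(CC)CCOC`, in this assay compound 3 gives 0.7 nM.
Compound 2, `CCC(CCOC)n1c(C2CC2)nc2c(-c3ccc(C(F)(F)F)cc3Cl)ccnc21`, in this assay compound 2 gives 20.8 nM.

Compound 1 has the lowest number of the three. Its value and that of compound 3 lie within the scatter of each other, so no order between them can be read. Among the compounds with values here, compound 2 stands far higher, and the one measured step, a 30-fold lower number from compound 2 to compound 3 (1.47 log units; beyond the scatter), shows a large change where an ethyl replaces a cyclopropyl on an aromatic carbon.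

Compound 4, `CCc1nc2c(-c3ccc(Cl)cc3Cl)ccnc2n1[C@H](CC)C1CC1`, has not been measured. (the two compounds have the same atoms and bonds and differ only in configuration as drawn: 1 of 1 stereo elements differ; a stereocentre at a saturated chain carbon is drawn S in compound 1 and R in compound 4). Within the data shown here, no measured step involves a change of configuration, so the step from compound 2 to compound 3 offers no direct guide. For compounds that are mirror images at a single stereocentre, affinity often differs markedly, and since compound 1 gives 0.4 nM, a number at the low end of this set, compound 4 is expected to give a higher number, with the step estimated as a 13-fold higher number from compound 1 to compound 4 (1.10 log units; beyond the scatter). The estimate for compound 4 in this assay is 5 nM, within a range from 0.4 nM to 60 nM.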

Compound 4, inhibition constant: 0.2 nM
Compound 4: middle estimate off by 25-fold (1.40 log units), on the high side, and the stated range ends above it.
By their numbers in this assay, from the lowest: compounds 4, 1 and 3 (each within the scatter of the next, the first and the last beyond it); then compound 2.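

In this assay, inverting the stereocentre at the saturated chain carbon gives a 2.0-fold lower number from compound 1 to compound 4 (0.30 log units; within the scatter), so the two mirror-image forms cannot be told apart on this read-out. The earlier compounds shown here showed only that swapping the ethyl and cyclopropyl groups on an aromatic carbon can matter a great deal; they said nothing about the configuration at this chain carbon, which here, with the rest of compound 1 unchanged, makes no readable difference. The comparison isolates that single feature, and what supports reading it this way is: the fact that compounds 1 and 4 differ only in the configuration as drawn

Going by these compounds, whether this tolerance holds with other groups on that carbon remains open, for example with a phenyl ring or a longer chain in place of the cyclopropyl. On these data alone, it is also open whether the mirror-image forms would stay this close with an amine on that chain.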